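A few compounds are considered here, and "the series" means these few. Any claim that something is new, unique, unknown or untested is made for them only; others in the source may bear on it.

Working notes on the series. In an ADME assay on HEL cells (Homo sapiens) for cytotoxicity, with a stated time of 3 days (a higher number here means that more compound is tolerated, a lower number that less compound is tolerated), compound 1 (`Cc1cc(-c2cccc([N+](=O)[O-])c2)c2ncc(CSCCc3ccccc3)n2c1`) gives 47 ug/mL and compound 2 (`Cc1cc(-c2cccc([N+](=O)[O-])c2)cn2c(CSCCc3ccccc3)cnc12`) gives 43 ug/mL as its reading. Compound 2 therefore stands with compound 1 inside the usual scatter, and the two cannot be ranked. Compound 3 (`Cc1cc(-c2cccc(O)c2)cn2c(CSCCc3ccccc3)cnc12`) keeps the rest of compound 2 and has hydroxy in place of nitro on an aromatic carbon. The change hydroxy in place of nitro on an aromatic carbon turns 3-nitrophenyl into 3-hydroxyphenyl. For the measured compounds named here, no measured pair shows what a change at this place does in this assay, so the only anchor is compound 2 at 43 ug/mL as read. The estimated step is a 1.1-fold lower number from compound 2 to compound 3 (0.03 log units; within the scatter) and no shift beyond the scatter is expected, although the uncertainty is wide. Compound 3 is expected at 40 ug/mL with an estimated range from 15 ug/mL to 100 ug/mL in this test.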

Compound 3, half-maximal cytotoxic concentration: 50 ug/mL
Compound 3: middle estimate off by 1.3-fold (0.10 log units), on the low side; the measured number falls inside the stated range.
By their numbers in this assay, from the lowest: compounds 2, 1 and 3 (each within the scatter of the next).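

In this assay, for the compounds shown here, hydroxy in place of nitro on an aromatic carbon, which turns 3-nitrophenyl into 3-hydroxyphenyl, gives a 1.2-fold higher number from compound 2 to compound 3 (0.07 log units; within the scatter) and provides the only measured pair at this place. The tolerated concentration therefore does not separate compound 2 from compound 3, even though a group of 3 heavy atoms with no hydrogen-bond donor gives way to one of 1 heavy atom with 1 hydrogen-bond donor. No evidence is available that accounts for this result.

On these data alone, whether an amine, a carboxylic acid or a methoxy group on this aromatic carbon would also stay within the scatter remains open. Going by these compounds alone, also open is whether hydroxy in place of nitro would read the same way on the core of compound 1, which has no such pair here.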